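The source may hold more compounds than are shown below. What is called first, only, known or untested is meant among the compounds shown, and "the series" means these compounds.

Compound 1 `CCn1cc(-c2nc3ccccc3[nH]2)c(=O)c2cc(F)c(N3CCNCC3)cc21` carries a 1H-benzimidazol-2-yl group on its core; in a functional assay on A549 cells (Homo sapiens) for cytotoxicity, read by sulforhodamine B assay, with a stated time of 48 h (on this read-out lower numbers stand for stronger inhibition and higher numbers for weaker inhibition), compound 1 gives 4700 nM. Its close relative compound 2 `CCn1cc(-c2nc3ccccc3[nH]2)c(=O)c2cc(F)c(N3CCNCC3)nc21` gives 7800 nM in this assay, and the two numbers lie within the usual scatter of each other, so neither stands apart. Compound 3 `CCn1cc(-c2nc3ccc(Cl)cc3[nH]2)c(=O)c2cc(F)c(N3CCNCC3)cc21` has not yet been measured. It differs from compound 1 by chloro in place of hydrogen on an aromatic carbon. Among the measured compounds shown here, no measured pair here shows what this change does, so the step expected in this assay is small, a shift toward a somewhat lower number if anything beyond the scatter. Compound 3 is therefore estimated at about 3000 nM, between 1200 nM and 8000 nM, an expected step of a 1.6-fold lower number from compound 1 to compound 3 (0.19 log units; within the scatter).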

Compound 3, half-maximal inhibitory concentration: 500 nM
Estimate against measurement, compound 3: 6.0-fold (0.78 log units) above; the whole stated range lies above it.
By their numbers in this assay, from the lowest: compound 3; then compounds 1 and 2 (each within the scatter of the next).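

In this assay the change from 1H-benzimidazol-2-yl to 6-chloro-1H-benzimidazol-2-yl brings a 9.4-fold lower number from compound 1 to compound 3 (0.97 log units; beyond the scatter) and stands beyond the scatter. Compounds 1 and 2 alone gave no such separation; this aromatic carbon is a place where a single chlorine atom changes the number clearly. Nothing shown here accounts for the size of this step.

Still open, going by these compounds, is whether fluoro, bromo, methoxy or an amine at this carbon would act like chloro. Also open, on these data alone, is whether chloro would bring a similar step on the core of compound 2.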